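Swapping a methyl ester for a primary amide on two different cores

The source may report more compounds than this note shows. Statements on the series, on what has been measured and on what is new or still open speak of the compounds shown alone.

Measured compounds:
compound 1, `COC(=O)c1cnc(C(=O)CCc2ccc(Oc3ccccc3)cc2)o1`: 1.7 nM
compound 2, `NC(=O)c1cnc(C(=O)CCc2ccc(Oc3ccccc3)cc2)o1`: 6.6 nM
compound 3, `COC(=O)c1ccc(-c2cnc(CCCc3ccc(-c4ccccc4)cc3)o2)nc1`: 50000 nM

Compound 1 and compound 2 share one core and differ at a single spot: amino in place of methoxy on a carbonyl carbon. In an assay for inhibition of Fatty-acid amide hydrolase 1 (Rattus norvegicus) (a lower number here means a stronger inhibitor, a higher number a weaker inhibitor), compound 1 gives 1.7 nM, while compound 2 gives 6.6 nM. That change made a step of a 3.9-fold higher number from compound 1 to compound 2 (0.59 log units; beyond the scatter), so on this core the amide is the somewhat weaker of the two.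

Compound 3 is built on a different core, and the difference between the two cores is not broken down here. In this assay compound 3 gives 50000 nM, far weaker than either compound 1 or compound 2.

Compound 4, `NC(=O)c1ccc(-c2cnc(CCCc3ccc(-c4ccccc4)cc3)o2)nc1`, has not yet been measured. It relates to compound 3 exactly as compound 2 relates to compound 1: amino in place of methoxy on a carbonyl carbon. The place of the change is the same in both pairs, so this is the same change seen a second time, only on a weaker core. If the change behaves as it did before, compound 4 would be expected to land slightly weaker than compound 3, a step of about a 1.2-fold higher number from compound 3 to compound 4 (0.08 log units; within the scatter), resting on the earlier step of a 3.9-fold higher number from compound 1 to compound 2 (0.59 log units; beyond the scatter) and on the value of compound 3, 50000 nM. Since compound 3 already sits at a very high number, the assay may simply report a limit for compound 4. The estimate for compound 4 in this assay is 60000 nM, with a likely range from 20000 nM to 150000 nM.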

Compound 4, inhibition constant: 30000 nM
For compound 4 the middle estimate is 2.0-fold (0.30 log units) above the measured one, within the range that was stated.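

On the core of compound 3, the same swap of methoxy for amino on a carbonyl carbon gives a 1.7-fold lower number from compound 3 to compound 4 (0.22 log units; within the scatter), so this assay does not separate these two compounds. The change therefore did not carry over from one core to the other with the size it had on the core of compound 1, and the comparison of the two steps makes this plain: the same change on two cores in this assay, a 3.9-fold higher number (0.59 log units; beyond the scatter) from compound 1 to compound 2 and a 1.7-fold lower number (0.22 log units; within the scatter) from compound 3 to compound 4, 6.5-fold (0.81 log units) apart, beyond the scatter of two such steps. Going by these compounds alone, this shows that, in this series, a step measured on one core cannot simply be added to a compound on another core, but with only two pairs, one of them made up of two very weak compounds, it does not show what sets the two steps apart or how the change would behave on any third core.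

The compounds shown leave open which of the several differences between the two cores matters most, as no pair here differs in just one of them. They also leave open how other groups on the same carbonyl carbon, such as a carboxylic acid or a methylamino group, would compare with methoxy and amino on each core.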